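This account rests on a few compounds, and the source may have more. Where it says the series, first, only, none or still open, it means among the compounds named here.

Compound 1 `O=C(NCCCCc1ccccc1)n1c(=O)oc2cc([N+](=O)[O-])ccc21`: 3 nM
Compound 2 `O=C(NCCCCc1ccccc1)n1c(=O)oc2c(Br)cccc21`: 18 nM

Of the compounds shown here, two have so far been measured in an assay on HEK293 cells for inhibition of acid ceramidase (Homo sapiens), with a stated time of 10 min; on this read-out lower numbers stand for stronger inhibition and higher numbers for weaker inhibition. Compound 1 gives 3 nM, and compound 2 gives 18 nM. Of the two numbers, that of compound 1 is the lower, and the gap to compound 2 lies beyond the usual scatter, so compound 1 is the stronger inhibitor of the pair. Going by the values given here, the two compounds differ in more than one place, so their values show only that the pair spans a real gap and say nothing about any single change.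

The third compound, compound 3 `O=C(NCCCCc1ccccc1)n1c(=O)oc2cc(-c3ccccc3)ccc21`, has not yet been measured. It arises from compound 1 by phenyl in place of nitro on an aromatic carbon. Among the compounds with values here, no measured pair shows this change on the shared core, so the size of the step rests on expectation alone. In this assay the expected move is toward weaker inhibition and beyond the scatter, a step of a 5.0-fold higher number from compound 1 to compound 3 (0.70 log units; beyond the scatter). Compound 3 is accordingly estimated at 15 nM, with a range from 3 nM to 80 nM.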

Compound 3, half-maximal inhibitory concentration: 84 nM
The estimate for compound 3 lay 5.6-fold (0.75 log units) below the measured number; measured number outside the range, above it.
By their numbers in this assay, from the lowest: compound 1; then compound 2; then compound 3.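

In this assay, going by these compounds alone, the exchange of nitro for phenyl on this aromatic carbon, meta to a fused ring and para to a fused ring, gives a 28-fold higher number from compound 1 to compound 3 (1.45 log units; beyond the scatter), a large step and the first change in a single place to be measured on the shared core. It shows that this carbon is not indifferent to the group it carries: a group of three heavy atoms with two hydrogen-bond acceptors gives way to an all-carbon aromatic ring with none, and the number rises well beyond the scatter, with compound 3 at 84 nM. Nothing available here bears on what lies behind this step.

From the compounds shown here alone, with only nitro and phenyl compared on this carbon, the two values mark out a single step and no trend, so it remains open whether an amine, a methoxy group or a chlorine atom there would give a number nearer that of compound 1 or that of compound 3. Within the data shown here, it is equally open whether the same exchange would bring a step of similar size on another carbon of the core, such as the one carrying bromine in compound 2.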